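Working notes: varying the substituent on the benzylic carbon

The compounds below may be only part of what the source reports. "The series", "measured", "known", "first", "only" and "open" are said of these compounds alone.

Measured so far in a functional assay (aorta) for antagonist activity, with Oryctolagus cuniculus as the target; on this read-out higher numbers stand for weaker inhibition and lower numbers for stronger inhibition:
compound 1 `CCCCc1ccc(CNC(=O)N(C)C)c(=O)n1Cc1ccc(-c2ccccc2-c2nn[nH]n2)cc1` — 2 nM
compound 2 `CCCCc1ccc(CN(Cc2ccccc2)C(C)=O)c(=O)n1Cc1ccc(-c2ccccc2-c2nn[nH]n2)cc1` — 1 nM

Compound 2 gives the lower of the two numbers in this assay, but the step of a 2.0-fold lower number from compound 1 to compound 2 (0.30 log units; within the scatter) stays within the scatter, so no order between compound 1 and compound 2 is claimed.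

Compound 3 `CCCCc1ccc(CN(C(C)C)S(C)(=O)=O)c(=O)n1Cc1ccc(-c2ccccc2-c2nn[nH]n2)cc1` has not been measured. Relative to compound 2 the change is isopropyl(methylsulfonyl)amino in place of acetyl(benzyl)amino on a saturated chain carbon bound to an aromatic carbon. Among the compounds with values here, the only measured step at this place is the one from compound 1 to compound 2, which stayed within the scatter; it is the sole guide here, and the entering group differs more from the acetyl(benzyl)amino group than the (dimethylcarbamoyl)amino group did. Within the data shown here, the expectation for compound 3 is therefore a step of a 3.0-fold higher number from compound 2 to compound 3 (0.48 log units; beyond the scatter) in this assay, with a wide range because the single step of a 2.0-fold lower number from compound 1 to compound 2 (0.30 log units; within the scatter) does not fix the direction. The estimate for compound 3 is 3 nM, expected to lie between 0.7 nM and 15 nM.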

Compound 3, half-maximal inhibitory concentration: 0.9 nM
Estimate against measurement, compound 3: 3.3-fold (0.52 log units) above; the range from low to high includes it.
By their numbers in this assay, from the lowest: compounds 3, 2 and 1 (each within the scatter of the next, the first and the last beyond it).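

In this assay the place on the saturated chain carbon bound to an aromatic carbon tolerates the loss of the six-membered aromatic ring: replacing acetyl(benzyl)amino with the ringless isopropyl(methylsulfonyl)amino gives a 1.1-fold lower number from compound 2 to compound 3 (0.05 log units; within the scatter). Against the (dimethylcarbamoyl)amino group, the same entering group gives a 2.2-fold lower number from compound 1 to compound 3 (0.35 log units; beyond the scatter), the first step at this place to pass the scatter, though only modestly, and the only order the three values support. No measurement available here accounts for either step.

The isopropyl and methylsulfonyl parts changed together, so their separate contributions remain unresolved. All three groups carry a carbonyl or a sulfonyl on the nitrogen, which leaves open how a plain tertiary amine or a carboxylic acid would fare at this place.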